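The source may report more compounds than this note shows. Statements on the series, on what has been measured and on what is new or still open speak of the compounds shown alone.

In a functional assay on MCF7 cells (Homo sapiens) for inhibition, read by MTT assay, with a stated time of 3 days (on this read-out lower numbers stand for stronger inhibition and higher numbers for weaker inhibition), compound 1 `COc1ccc(/C=C\c2cc(OC)c(OC)c(OC)c2)cc1OCc1ccccc1` gives 59000 nM, compound 2 `COc1ccc(/C=C\c2cc(OC)c(OC)c(OC)c2)cc1OCc1ccc(Br)cc1` gives 29000 nM and compound 3 `COc1ccc(/C=C/CCCOc2cc(/C=C\c3cc(OC)c(OC)c(OC)c3)ccc2OC)cc1` gives 16000 nM. The nearest gap is a 1.8-fold lower number from compound 2 to compound 3 (0.26 log units; within the scatter), and the widest is a 3.7-fold lower number from compound 1 to compound 3 (0.57 log units; beyond the scatter). Compound 4 `COc1ccc(/C=C\c2cc(OC)c(OC)c(OC)c2)cc1OCCC/C=C/c1ccc(F)cc1` has not yet been measured. It carries fluoro in place of methoxy on an aromatic carbon, para to a large group (fluoro in place of methoxy on an aromatic carbon). Within the data shown here, no measured step exchanges methoxy for fluoro. Among the measured compounds shown here, the closest precedent is a modest one, a 2.0-fold lower number from compound 1 to compound 2 (0.31 log units; beyond the scatter), with bromo in place of hydrogen on an aromatic carbon. The estimated step is a 1.1-fold lower number from compound 3 to compound 4 (0.06 log units; within the scatter), so no change beyond the scatter is expected in this assay. Compound 4 is expected at about 14000 nM, with an estimated range from 6000 nM to 35000 nM.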

Compound 4, half-maximal inhibitory concentration: 16000 nM
For compound 4 the middle estimate is 1.1-fold (0.06 log units) below the measured one; low and high end bracket the measured number.
By their numbers in this assay, from the lowest: compounds 3, 4 and 2 (each within the scatter of the next); then compound 1.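

In this assay, putting fluoro in place of methoxy on an aromatic carbon, para to a large group, leaves the number where it was (no change at the digits printed from compound 3 to compound 4 (within the scatter)). Among these compounds, at this end of the chain, the 4-fluorophenyl group therefore holds the same place as the 4-methoxyphenyl group relative to the shorter benzyl ethers (a 1.8-fold lower number from compound 2 to compound 4 (0.26 log units; within the scatter); a 3.7-fold lower number from compound 1 to compound 4 (0.57 log units; beyond the scatter)), and only the step from the unsubstituted benzyl ether lies beyond the scatter. No evidence given here accounts for this result. As far as these compounds go, whether an amine or a carboxylic acid at this ring carbon, or a longer chain, would shift the number remains open.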